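This account rests on a few compounds, and the source may have more. Where it says the series, first, only, none or still open, it means among the compounds named here.

Of the compounds shown here, two have numbers so far. Compound 1 `CCCCCCCCCCc1ccc(-c2noc(CCCN)n2)cc1` gives 67% in an assay on HeLa cells for inhibition of sphingosine-1-phosphate transporter SPNS2 (Mus musculus), read by LC-MS, tested at 2 uM; a lower number here means less inhibition, a higher number more inhibition at the concentration tested (going by the name of the read-out). Going by the values given here, compound 2 `CCCCCCCCCCc1ccc(-c2noc(CCCNC)n2)cc1` gives 45% in the same test, which places it as the lower of the two; the only measured step, methyl in place of hydrogen on an amine nitrogen, is a number 22 percentage points lower from compound 1 to compound 2 (beyond the scatter).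

Compound 3 `CCCCCCCCCCc1ccc(-c2noc([C@H]3CCCN3)n2)cc1` differs from compound 2 in one place: pyrrolidin-2-yl in place of 3-(methylamino)propyl on an aromatic carbon. The nitrogen stays a secondary amine but now sits within the five-membered ring. Among the compounds with values here, no measured step covers closing a chain into a ring, and the methylation step from compound 1 to compound 2 speaks only to substitution on the nitrogen, so no direction can be taken from it with confidence. Compound 3 is therefore expected to land near compound 2, with a step of a number 5 percentage points higher from compound 2 to compound 3 (within the scatter) that may not clear the scatter. The estimate for compound 3 is 50%, within a range of 30% to 72%.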

Compound 3, a percentage reported as inhibition, at one concentration (the size of the read-out at that concentration, not a potency): 12%
Compound 3: the middle estimate sits 38 percentage points above what was measured; measured number outside the range, below it.
By their numbers in this assay, from the lowest: compound 3; then compound 2; then compound 1.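

Swapping the open 3-(methylamino)propyl chain for pyrrolidin-2-yl on this aromatic carbon leaves the counts of heavy atoms, hydrogen-bond donors and hydrogen-bond acceptors unchanged, yet in this assay it gives a number 33 percentage points lower from compound 2 to compound 3 (beyond the scatter). Pyrrolidin-2-yl in place of 3-aminopropyl gives a number 55 percentage points lower from compound 1 to compound 3 (beyond the scatter), so the number at this position responds to more than substitution on the amine nitrogen, the only change the earlier step covered. No evidence is available on what lies behind these drops.

The compounds shown leave open whether the loss belongs to the ring itself or to the shorter open stretch of chain, which an unbranched 2-aminoethyl group could separate. They also leave open how piperidin-2-yl, azetidin-2-yl or the opposite configuration of pyrrolidin-2-yl would compare with compound 3.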